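The source may report more compounds than this note shows. Statements on the series, on what has been measured and on what is new or still open speak of the compounds shown alone.

Measured so far in a functional assay on HeLa cells (Homo sapiens) for cytotoxicity, read by MTT assay, with a stated time of 3 days; a higher number here means a weaker inhibitor, a lower number a stronger inhibitor:

compound 1 `CC(C)CCOC(=O)Nc1nc(=O)n([C@@H]2O[C@H](C)[C@@H](O)[C@H]2O)cc1F`: 90 ug/mL
compound 2 `CCC(C)COC(=O)Nc1nc(=O)n([C@@H]2O[C@H](C)[C@H]3OC(=O)O[C@H]32)cc1F`: 180 ug/mL

Compound 2 holds the higher of the two numbers, with compound 1 nearest; the gap between compound 1 and compound 2 lies within the scatter, so the two cannot be ranked against each other in this assay. Going by the values given here, no step between the two measured compounds is available, since the two structures differ in more than one place.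

Compound 3 `CCCCCOC(=O)Nc1nc(=O)n([C@@H]2O[C@H](C)[C@H]3OC(=O)O[C@H]32)cc1F` has not been measured. It differs from compound 2 in one place: butyl in place of sec-butyl on a saturated chain carbon bound to an oxygen next to a carbonyl group The two have the same atoms, joined differently. Among the compounds with values here, with nothing measured on this kind of change and only two values, both within the scatter of each other, the step from compound 2 to compound 3 is expected to stay within the scatter, in no particular direction. On that basis compound 3 is expected to give about 180 ug/mL in this assay, between 90 ug/mL and 360 ug/mL, an estimated step of no change at the digits printed from compound 2 to compound 3 (within the scatter).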

Compound 3, half-maximal inhibitory concentration: 80 ug/mL
For compound 3 the middle estimate is 2.3-fold (0.35 log units) above the measured one, outside the stated range (below it).
By their numbers in this assay, from the lowest: compounds 3, 1 and 2 (each within the scatter of the next, the first and the last beyond it).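

Going by these compounds alone, the pentyloxycarbonyl and (2-methylbutoxy)carbonyl pair gives the first readable step at this position: in this assay, butyl in place of sec-butyl on a saturated chain carbon bound to an oxygen next to a carbonyl group gives a 2.3-fold lower number from compound 2 to compound 3 (0.35 log units; beyond the scatter), modest but beyond the scatter. The two compounds have the same atoms, joined differently, so a change in how the chain is joined is enough to move the number on this core, although this rests on a single pair. No measurement shown here offers an explanation for the step.

As far as these compounds go, it remains open whether the same change gives a similar step on the core of compound 1. From the compounds shown here alone, it is also open whether a longer chain such as hexyl, or a chain ending in an amine, would extend or reverse this step.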